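The compounds below may be only part of what the source reports. "The series", "measured", "known", "first", "only" and "open" are said of these compounds alone.

Compound 1 `O=C1C2=C(C(=O)c3ncccc31)C1(CS2)NC(=O)N(c2ccccc2)C1=O` was tested in a functional assay on SF-268 cells (Homo sapiens) for antiproliferative activity, read by MTT assay, with a stated time of 96 h (on this read-out higher numbers stand for weaker inhibition and lower numbers for stronger inhibition), where compound 1 gives 1700 nM. Among the measured compounds shown here, only one other compound has been measured alongside it: compound 2 `O=C1C2=C(C(=O)c3ncccc31)C1(CS2)NC(=O)N(c2ccc([N+](=O)[O-])cc2)C1=O`, which carries a nitro group in place of a hydrogen on the phenyl ring and which in this assay gives 1520 nM. The step of a 1.1-fold lower number from compound 1 to compound 2 (0.05 log units; within the scatter) shows that this substitution left the antiproliferative read-out essentially unchanged, so compound 1 and compound 2 cannot be told apart on these numbers.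

Compound 3 `Cc1ccc(N2C(=O)NC3(CSC4=C3C(=O)c3ncccc3C4=O)C2=O)cc1` is the next change at the same phenyl ring: methyl in place of hydrogen on an aromatic carbon. For the measured compounds named here, the only comparison that bears on it is the step from compound 1 to compound 2, and that step lay within the scatter. A small substituent placed at the same position of the ring therefore gives no reason to expect a shift beyond the scatter in this assay, in either direction.

The expected outcome for compound 3 is thus a value close to that of compound 1, estimated at 1700 nM with a range from 800 nM to 3600 nM, corresponding to an expected step of no change at the digits printed from compound 1 to compound 3 (within the scatter).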

Compound 3, half-maximal inhibitory concentration: 660 nM
For compound 3 the middle estimate is 2.6-fold (0.41 log units) above the measured one, outside the stated range (below it).
By their numbers in this assay, from the lowest: compound 3; then compounds 2 and 1 (each within the scatter of the next).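

The phenyl ring position para to a large group turns out to respond to what sits there, which the first pair could not show: in this assay, methyl in place of hydrogen gives a 2.6-fold lower number from compound 1 to compound 3 (0.41 log units; beyond the scatter), a step beyond the scatter. Methyl in place of nitro at that same position gives a 2.3-fold lower number from compound 2 to compound 3 (0.36 log units; beyond the scatter), so compound 3 stands apart from both earlier compounds, while those two remain indistinguishable from each other. This also means that adding any group to the ring does not by itself lower the number, since compound 2 goes against such a rule, and no measurement shown here explains why methyl differs from hydrogen and nitro.

Three compounds cannot show whether this step is particular to methyl or extends to a larger alkyl group such as ethyl or a longer chain. Going by these compounds, it also remains open how groups of other kinds at this position, such as methoxy, chlorine, an amine or a carboxylic acid, would compare with compound 3.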